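A few compounds are considered here, and "the series" means these few. Any claim that something is new, unique, unknown or untested is made for them only; others in the source may bear on it.

Measured in an assay on CHO cells for displacement of a labelled ligand from adenosine receptor A1 (Homo sapiens), read by scintillation counting, tested at 10 uM; a lower number here means less inhibition, a higher number more inhibition at the concentration tested (going by the name of the read-out):
compound 1 `Cc1csc(N)c1C(=O)c1ccc(Cl)cc1` gives 1%;
compound 2 `CC(C)(C)Cc1c(-c2ccc(F)cc2)sc(N)c1C(=O)c1ccc(Cl)cc1` gives 1%.

In this assay compound 2 stands level with compound 1 at the digits shown; the two values lie within the usual scatter, so neither is set apart from the other. Compound 3 `Cc1ccc(-c2sc(N)c(C(=O)c3ccc(Cl)cc3)c2CC(C)(C)C)cc1` differs from compound 2 in one place: methyl in place of fluoro on an aromatic carbon. Among the compounds with values here, no step between two measured compounds covers this change, so any expectation rests on the two measured values alone. The step of a number 1 percentage points higher from compound 2 to compound 3 (within the scatter) is expected to be none beyond the scatter. In this assay compound 3 is estimated at 2%, with a range from -5% to 12%.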

Compound 3, a percentage reported as inhibition, at one concentration (the size of the read-out at that concentration, not a potency): 1%
Compound 3: middle estimate off by 1 percentage points, on the high side; measured number inside the range.
By their numbers in this assay, from the lowest: compounds 1, 2 and 3 (each within the scatter of the next).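

In this assay, within the data shown here, methyl in place of fluoro on an aromatic carbon, the change from 4-fluorophenyl to 4-methylphenyl, gives no change at the digits printed from compound 2 to compound 3 (within the scatter) and is the first step read at this position. At this level of the read-out, the exchange of these two single-atom groups does not separate the compounds. Nothing available bears on this result. On these data alone, whether an amine or a carboxylic acid at this same aromatic carbon would separate from compound 2 stays open, as does what a longer chain there would give.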